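Trifluoromethyl in place of methylsulfanyl: an expected step

A few compounds are considered here, and "the series" means these few. Any claim that something is new, unique, unknown or untested is made for them only; others in the source may bear on it.

Of the compounds shown here, three have so far been measured in a physicochemical assay for solubility, at pH 7.4; on this read-out lower numbers stand for lower solubility and higher numbers for higher solubility. Compound 1 (`CSc1ccc(NC(=O)Nc2cc(C)nc3ccccc23)cc1`) gives 1300 nM and holds the lowest of the three numbers. Compound 3 (`COc1ccc(NC(=O)Nc2cc(C)nc3ccccc23)cc1F`) gives 2700 nM and compound 2 (`Cc1cc(NC(=O)Nc2ccc3[nH]cnc3c2)c2ccccc2n1`) gives 7300 nM as the highest number, and both stand beyond the usual scatter from compound 1.

Compound 4 (`Cc1cc(NC(=O)Nc2ccc(C(F)(F)F)cc2)c2ccccc2n1`) has not yet been measured. It carries trifluoromethyl in place of methylsulfanyl on an aromatic carbon of a six-membered aromatic ring of carbon only, para to a large group (trifluoromethyl in place of methylsulfanyl on an aromatic carbon). Among the compounds with values here, no two measured compounds differ in one place alone, so the data hold no direct precedent for this change, and nothing measured points to a rise. The expectation therefore stays close to compound 1 at 1300 nM as its anchor, with a small move towards lower numbers in this assay that may not clear the scatter. The estimate amounts to a step of a 1.4-fold lower number from compound 1 to compound 4 (0.16 log units; within the scatter) as the expected change. Compound 4 is estimated at 900 nM with an expected range from 300 nM to 2700 nM as its limits of confidence.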

Compound 4, solubility: 100 nM
Beside the measured number, compound 4's estimate is 9.0-fold (0.95 log units) above it; measured number outside the range, below it.
By their numbers in this assay, from the lowest: compound 4; then compound 1; then compound 3; then compound 2.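

In this assay, within the data shown here, putting trifluoromethyl in place of methylsulfanyl on an aromatic carbon of a six-membered aromatic ring of carbon only, para to a large group, gives a 13-fold lower number from compound 1 to compound 4 (1.11 log units; beyond the scatter), the first step in these data between two compounds that differ in one place. This shows that the position is not a silent one on this read-out: with the rest of the structure unchanged, this single exchange moves the number well beyond the usual scatter, so the shared core does not by itself set the value. Nothing measured here accounts for the size of the step, which stands as an observation without an explanation.

A single pair cannot separate what the departure of methylsulfanyl contributes from what the arrival of trifluoromethyl contributes, nor show whether the same exchange would give a step of similar size on another core. On these data alone, it also remains open where the number would lie with an amine, a carboxylic acid or a longer chain on this same aromatic carbon.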